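Chloropropyl to ethyl on a sulfonate and a sulfonamide urea

A few compounds are considered here, and "the series" means these few. Any claim that something is new, unique, unknown or untested is made for them only; others in the source may bear on it.

Compound 1 `Cc1ccccc1OS(=O)(=O)c1cccc(NC(=O)NCCCCl)c1`: 29000 nM
Compound 2 `Cc1ccccc1NS(=O)(=O)c1ccc(NC(=O)NCCCCl)cc1`: > 200000 nM
Compound 3 `CCNC(=O)Nc1cccc(S(=O)(=O)Oc2ccccc2C)c1`: 51000 nM

In a functional assay on M21 cells (Homo sapiens) for cytotoxicity, read by sulforhodamine B assay, with a stated time of 48 h (on this read-out higher numbers stand for weaker inhibition and lower numbers for stronger inhibition), compound 1 gives 29000 nM and compound 3 gives 51000 nM. The change from compound 1 to compound 3 is hydrogen in place of chloromethyl on a saturated chain carbon, two bonds along the chain from an amide-type nitrogen and the measured step is a 1.8-fold higher number from compound 1 to compound 3 (0.25 log units; within the scatter), so the two values cannot be told apart. Compound 2 is reported only as a limit of this assay, > 200000 nM; that is the limit of > 200000 nM in this assay, at which 1 of the 3 values shown sits.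

Compound 4 `CCNC(=O)Nc1ccc(S(=O)(=O)Nc2ccccc2C)cc1` has not yet been measured. It differs from compound 2 by hydrogen in place of chloromethyl on a saturated chain carbon, two bonds along the chain from an amide-type nitrogen, the same change already seen from compound 1 to compound 3. How the core of compound 2 differs from the core of compound 1 is not broken down here.

Among the compounds with values here, compound 4 is expected to move from compound 2 by a step that the limit leaves unreadable from compound 2 to compound 4, because the only measured instance of this change, a 1.8-fold higher number from compound 1 to compound 3 (0.25 log units; within the scatter), stays within the scatter. Compound 4 is therefore estimated at about 300000 nM, between 100000 nM and 1000000 nM, and will most likely again be reported only as a limit.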

Compound 4, half-maximal inhibitory concentration: > 200000 nM
Compound 4 was reported as a limit (the forecaster's own chance of this, stated with the estimate: 85%); the middle value lies beyond the limit too.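

Compound 2 and compound 4 are each reported only as a limit, so no step can be read from compound 2 to compound 4: the limit of > 200000 nM in this assay, at which 2 of the 4 values shown sit. The compounds shown leave open whether 3-chloropropyl to ethyl changes the read-out at all on the core of compound 2.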